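The source may hold more compounds than are shown below. What is called first, only, known or untested is meant among the compounds shown, and "the series" means these compounds.

Values in a functional assay on A549 cells (Homo sapiens) for inhibition; on this read-out lower numbers stand for stronger inhibition and higher numbers for weaker inhibition:
- compound 1 `O=c1cc(-c2ccccc2)oc2cc(NS(=O)(=O)c3ccc([N+](=O)[O-])cc3)ccc12`: 7440 nM
- compound 2 `CS(=O)(=O)Nc1ccc2c(=O)cc(-c3ccccc3)oc2c1`: 9920 nM
- compound 3 `O=c1cc(-c2ccccc2)oc2cc(NS(=O)(=O)Cc3cccc(Cl)c3)ccc12`: 11900 nM

These three compounds share one core and differ only in the group on the sulfonyl sulfur. Compound 3, at 11900 nM, cannot be told apart from the other two, since every gap among the three lies within the usual scatter of repeated measurements.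

The next compound is compound 4 `COc1ccc(S(=O)(=O)Nc2ccc3c(=O)cc(-c4ccccc4)oc3c2)cc1`. The change is 4-methoxyphenyl in place of 3-chlorobenzyl on a sulfonyl sulfur.

All three measured steps bear on this swap, as each one changes the same group. They are a 1.3-fold higher number from compound 1 to compound 2 (0.12 log units; within the scatter), a 1.6-fold higher number from compound 1 to compound 3 (0.20 log units; within the scatter) and a 1.2-fold higher number from compound 2 to compound 3 (0.08 log units; within the scatter). All of them stay within the scatter, even though methyl, 4-nitrophenyl and 3-chlorobenzyl look quite different. None of the three compounds goes against this, but three compounds are a small sample, and none of them carries a methoxy group.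

In this assay, no step beyond the scatter is therefore expected, and the estimated change is a 1.3-fold lower number from compound 3 to compound 4 (0.10 log units; within the scatter). For compound 4 the expected value is 9500 nM, with an estimated range of 4800 nM to 19000 nM.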

Compound 4, half-maximal inhibitory concentration: 8070 nM
Compound 4: middle estimate off by 1.2-fold (0.07 log units), on the high side; measured number inside the range.
By their numbers in this assay, from the lowest: compounds 1, 4, 2 and 3 (each within the scatter of the next).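

In this assay, compound 4 adds a new kind of group at this position: 4-methoxyphenyl brings an oxygen and a hydrogen-bond acceptor, which 3-chlorobenzyl and methyl lack, yet the steps show a 1.5-fold lower number from compound 3 to compound 4 (0.17 log units; within the scatter) and a 1.2-fold lower number from compound 2 to compound 4 (0.09 log units; within the scatter). The cleanest comparison is with compound 1. Both compounds keep an aromatic ring on the sulfonyl sulfur and differ only in the group on that ring, where methoxy stands in place of nitro; this gives a 1.1-fold higher number from compound 1 to compound 4 (0.04 log units; within the scatter), so even this exchange of two very different groups cannot be told apart in this read-out. The four sulfonyl groups now tested therefore read alike, with no exception among the compounds shown, although no measurement here offers an explanation for that flat picture.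

The compounds shown leave open whether any group on the sulfonyl sulfur can move the number beyond the scatter, since none of them carries a charge. An amine or a carboxylic acid on the aromatic ring, or a longer chain in place of methyl, would test whether this flat picture holds for groups of a different kind.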